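Replacing the Methoxy(methyl)amino Group with Propylamino

The source may hold more compounds than are shown below. What is called first, only, known or untested is meant among the compounds shown, and "the series" means these compounds.

Of the compounds shown here, three that share one core have so far been tested in a functional assay on the whole organism with Rattus norvegicus as the target, at a dose of 20 mg/kg by the oral route; on this read-out lower numbers stand for less inhibition and higher numbers for more inhibition at the one dose given (going by the name of the read-out). Compound 1 `O=C(/C=C1\CCc2ccc(F)cc21)NCCO` gives 42% in this assay. Compound 2 `CCNC(=O)/C=C1\CCc2ccc(F)cc21` gives 45% in this assay. Compound 3 `CON(C)C(=O)/C=C1\CCc2ccc(F)cc21` gives 6% in this assay, the lowest of the three numbers. Between the first two the change is small: a number 3 percentage points higher from compound 1 to compound 2 (within the scatter). The two steps that lead to compound 3 are another matter: a number 36 percentage points lower from compound 1 to compound 3 (beyond the scatter) and a number 39 percentage points lower from compound 2 to compound 3 (beyond the scatter), both large falls in inhibition.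

Compound 4 `CCCNC(=O)/C=C1\CCc2ccc(F)cc21` has not yet been measured. It differs from compound 3 in one place: propylamino in place of methoxy(methyl)amino on a carbonyl carbon. The group that enters resembles the ethylamino of compound 2 and the (2-hydroxyethyl)amino of compound 1 in carrying a hydrogen-bond donor, which the methoxy(methyl)amino of compound 3 lacks. The two large downward steps to compound 3 are therefore the ones that bear on this change, and they point to a large rise in the other direction, a number 36 percentage points higher from compound 3 to compound 4 (beyond the scatter) being the expected step. Compound 4 is accordingly expected to give about 42% in this assay, with a likely range from 25% to 58%.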

Compound 4, a percentage reported as inhibition, in the whole organism at one dose (the size of the read-out at that dose, not a potency): 0%
The estimate for compound 4 lay 42 percentage points above the measured number, and the stated range ends above it.
By their numbers in this assay, from the lowest: compounds 4 and 3 (each within the scatter of the next); then compounds 1 and 2 (each within the scatter of the next).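

Swapping methoxy(methyl)amino for propylamino on the carbonyl carbon produces no real change in this assay, with a number 6 percentage points lower from compound 3 to compound 4 (within the scatter), so gaining a hydrogen-bond donor at this place is not enough on its own to reach the higher numbers of compound 1 and compound 2. Going by these compounds alone, the chain itself matters more than the earlier compounds suggested: methyl in place of hydrogen at its end gives a number 45 percentage points lower from compound 2 to compound 4 (beyond the scatter), and methyl in place of hydroxy gives a number 42 percentage points lower from compound 1 to compound 4 (beyond the scatter), even though hydrogen in place of that hydroxy gave only a number 3 percentage points higher from compound 1 to compound 2 (within the scatter). No measured evidence is available to explain why this small extension of the chain goes with such a large fall.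

As far as these compounds go, whether a hydroxy at the end of the longer chain, as in 3-hydroxypropylamino, would return the number to the level of compound 1 remains open. So does the behaviour of a shorter methylamino, a branched isopropylamino or a still longer butylamino, which would show whether ethylamino marks a limit on chain size or compound 4 is a single low point.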